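Swapping a methyl for a triazolylcarbonyl on the ring nitrogen

A few compounds are considered here, and "the series" means these few. Any claim that something is new, unique, unknown or untested is made for them only; others in the source may bear on it.

The two measured compounds share a core and differ in what sits on the ring nitrogen. Compound 1 `O=C(C1CCN(c2ccncn2)CC1)N1N=CC[C@H]1c1ccccc1` carries a pyrimidinyl there, and in a physicochemical assay for lipophilicity, read by HPLC, measured as chromatographic lipophilicity, at pH 7.4 (on this read-out higher numbers stand for higher lipophilicity and lower numbers for lower lipophilicity), compound 1 gives 3.2. Compound 2 `CN1CCC(C(=O)N2N=CCC2c2ccccc2)CC1` carries a methyl, and in this assay compound 2 gives 1.1, the lower of the two numbers, with compound 1 standing well beyond the scatter above it.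

Compound 3 `O=C(c1c[nH]nn1)N1CCC(C(=O)N2N=CCC2c2ccccc2)CC1` is not yet measured. It differs from compound 2 as follows: (1H-1,2,3-triazol-4-yl)carbonyl in place of methyl on an amine nitrogen in a ring. Since compound 1, which also lacks the methyl, shows 3.2, an upward step is expected. The step of a number 1.10 log units higher from compound 2 to compound 3 (beyond the scatter) is expected to be upward and beyond the scatter, though not as far as compound 1 goes. Compound 3 is therefore estimated at 2.2, within a range from 1.4 to 3.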

Compound 3, distribution coefficient: 2
Estimate against measurement, compound 3: 0.20 log units above; the range from low to high includes it.
By their numbers in this assay, from the lowest: compound 2; then compound 3; then compound 1.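

On an amine nitrogen in a ring, putting (1H-1,2,3-triazol-4-yl)carbonyl in place of methyl gives, in this assay, a number 0.90 log units higher from compound 2 to compound 3 (beyond the scatter). For the compounds shown here, this is the first change at this position that can be read on its own, since only this one place differs, and it shows that the number rises even though the entering group brings a five-membered aromatic ring, a hydrogen-bond donor and hydrogen-bond acceptors. Nothing measured here explains the rise.

A single step cannot tell how much of the rise belongs to the carbonyl, how much to the triazole ring, and how much to the loss of the methyl. An acetyl or a benzoyl on this nitrogen, or simply a hydrogen there, would help to pull those parts apart.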